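Sulfone aryl exchange in a quinoline series: clearance notes

A few compounds are considered here, and "the series" means these few. Any claim that something is new, unique, unknown or untested is made for them only; others in the source may bear on it.

Compound 1 `O=S(=O)(c1ccc(F)c(Cl)c1)c1cnc2cc(F)ccc2c1-c1cccc(F)c1` gives 0.25 mL/min in an ADME assay on microsomes from liver (Homo sapiens) for metabolic stability, tested at 2.5 uM; a lower number here means slower removal, a higher number faster removal of the compound.
Compound 2 `COc1ccc(-c2c(S(=O)(=O)c3ccc(F)c(Cl)c3)cnc3cc(F)ccc23)cc1` gives 1.08 mL/min in this assay.
Compound 3 `O=S(=O)(c1ccc(F)c(Cl)c1)c1cnc2cc(F)ccc2c1-c1ccc(Cl)cc1` gives 0.39 mL/min in this assay.

Compound 2 stands highest of the three numbers, with a 4.3-fold higher number from compound 1 to compound 2 (0.64 log units; beyond the scatter) and a 2.8-fold lower number from compound 2 to compound 3 (0.44 log units; beyond the scatter) both beyond the scatter, while a 1.6-fold higher number from compound 1 to compound 3 (0.19 log units; within the scatter) stays within it. Compound 4 `COc1ccc(-c2c(S(=O)(=O)c3ccc(OC)cc3)cnc3cc(F)ccc23)cc1` differs from compound 2 at the sulfonyl sulfur: 4-methoxyphenyl in place of 3-chloro-4-fluorophenyl on a sulfonyl sulfur. Within the data shown here, no measured step touches that position; the steps that bear on it concern the other aryl group only, where methoxy against fluoro and chloro gave the larger numbers. Taking those as a loose guide, a further methoxyphenyl is expected to move the number in the same direction, a 1.9-fold higher number from compound 2 to compound 4 (0.27 log units; within the scatter) being the estimated step. Compound 4 is therefore expected to give about 2 mL/min, within 0.9 mL/min to 4.5 mL/min.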

Compound 4, intrinsic clearance in a liver preparation (reported as CLH), per the amount of preparation that the assay uses: 1.18 mL/min
The estimate for compound 4 lay 1.7-fold (0.23 log units) above the measured number; the measured number falls inside the stated range.
By their numbers in this assay, from the lowest: compounds 1 and 3 (each within the scatter of the next); then compounds 2 and 4 (each within the scatter of the next).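

At the sulfonyl sulfur, 4-methoxyphenyl in place of 3-chloro-4-fluorophenyl leaves compound 2 and compound 4 level in this assay (a 1.1-fold higher number from compound 2 to compound 4 (0.04 log units; within the scatter)). The chlorine and fluorine of the leaving group are thus not needed to hold this read-out within the scatter at this position, whereas the exchange on the other aryl group gave a step beyond it (a 4.3-fold higher number from compound 1 to compound 2 (0.64 log units; beyond the scatter)). No supporting measurement explains the difference between the two positions.

From the compounds shown here alone, whether this flat step holds with 3-fluorophenyl or 4-chlorophenyl on the shared core remains open. So does the effect of an amine or a carboxylic acid on the sulfonyl aryl ring.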